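A few compounds are considered here, and "the series" means these few. Any claim that something is new, unique, unknown or untested is made for them only; others in the source may bear on it.

Measured so far:
compound 1 `Cc1cc(S(N)(=O)=O)ccc1NC(=O)COc1ccc(Cl)cc1NC(=O)c1ccccc1` – 207000 nM
compound 2 `Cc1cc(S(N)(=O)=O)ccc1NC(=O)COc1ccc(Cl)cc1NC(=O)c1ccccc1C` – 67300 nM
compound 3 `Cc1cc(S(N)(=O)=O)ccc1NC(=O)COc1ccc(Cl)cc1NC(=O)c1cccc(F)c1` – 243000 nM

In a functional assay on C8166 cells (Homo sapiens) for cytotoxicity, read by MTT assay (a lower number here means that less compound is tolerated, a higher number that more compound is tolerated), compound 3 gives 243000 nM. Its standing follows from two steps: a 1.2-fold higher number from compound 1 to compound 3 (0.07 log units; within the scatter) and a 3.6-fold higher number from compound 2 to compound 3 (0.56 log units; beyond the scatter).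

Compound 4 `Cc1cc(S(N)(=O)=O)ccc1NC(=O)COc1ccc(Cl)cc1NC(=O)c1ccccc1[N+](=O)[O-]` has 2-nitrophenyl in place of 3-fluorophenyl on a carbonyl carbon.

Within the data shown here, no measured compound carries a nitro group, so any guide is indirect. Among the measured compounds shown here, the nearest is compound 2, whose 2-methylphenyl is the only measured group numbered like 2-nitrophenyl: a 3.1-fold lower number from compound 1 to compound 2 (0.49 log units; beyond the scatter). That is a single modest step, and a methyl group is not a nitro group, so the expectation is weak. A modest move to a lower number in this assay is expected, with a range that still takes in no change. The expected step is a 2.7-fold lower number from compound 3 to compound 4 (0.43 log units; beyond the scatter). The estimate for compound 4 is 90000 nM, with an expected range of 35000 nM to 220000 nM.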

Compound 4, half-maximal cytotoxic concentration: 54800 nM
The estimate for compound 4 lay 1.6-fold (0.22 log units) above the measured number, and the stated range covers the measured number.
By their numbers in this assay, from the lowest: compounds 4 and 2 (each within the scatter of the next); then compounds 1 and 3 (each within the scatter of the next).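

In this assay, 2-nitrophenyl on the carbonyl carbon gives a lower number than the unsubstituted phenyl of compound 1 and the 3-fluorophenyl of compound 3, with a 3.8-fold lower number from compound 1 to compound 4 (0.58 log units; beyond the scatter) and a 4.4-fold lower number from compound 3 to compound 4 (0.65 log units; beyond the scatter) as the two steps. Nitro in place of methyl makes no readable difference, with a 1.2-fold lower number from compound 2 to compound 4 (0.09 log units; within the scatter) as the step, so the lower number seen with 2-methylphenyl is now shared by a second, quite different group, and the series falls into two tiers: compound 2 and compound 4, then compound 1 and compound 3. No evidence on the origin of this shared lower number is at hand.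

Two groups are too few to show how general this is. From the compounds shown here alone, it remains open whether an amine or a carboxylic acid on the same phenyl ring would join the lower tier or stay with compound 1 and compound 3.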